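The source may report more compounds than this note shows. Statements on the series, on what has been measured and on what is new or still open speak of the compounds shown alone.

Of the compounds shown here, two have so far been tested in a functional assay on the whole organism (strain Swiss albino) with Mus musculus as the target, with a stated time of 0.5 h; a higher number here means that more compound is needed for the effect, a lower number that less compound is needed. Compound 1, `COc1cc(/C=N/Cc2cccnc2)ccc1O`, is the starting point of the step followed here. In this assay compound 1 gives 30 mg/kg. Compound 2, `c1cncc(CN=C2CCCCC2)c1`, is built on a different core, and in this assay compound 2 gives 30 mg/kg. The two readings are level at the digits shown, and the gap between them lies within the usual scatter of repeated measurements, so neither compound can be called more or less effective than the other.

Compound 3, `COc1ccc(/C=N/Cc2cccnc2)cc1OC`, has not yet been measured. It differs from compound 1 in one place: methyl in place of hydrogen on an oxygen on an aromatic ring. Among the measured compounds shown here, no pair of measured compounds shows the effect of exactly this change, so there is no measured step to lean on. For the measured compounds named here, the one comparison available, between compound 1 and compound 2, shows two rather different structures giving the same reading, which gives no hint that a small change would move the number far. A step no larger than the scatter is therefore expected, no change at the digits printed from compound 1 to compound 3 (within the scatter), with no clear direction. The estimated value for compound 3 in this assay is 30 mg/kg, with a range from 10 mg/kg to 100 mg/kg.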

Compound 3, minimum effective dose: 30 mg/kg
Beside the measured number, compound 3's estimate shows no gap at the digits printed, and the stated range covers the measured number.
By their numbers in this assay, from the lowest: compounds 1, 2 and 3 (each within the scatter of the next).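

In this assay, among the compounds shown here, the change of hydroxy to methoxy gives no change at the digits printed from compound 1 to compound 3 (within the scatter) and is the first measured step at this oxygen on the aromatic ring. It shows that methyl can take the place of the hydrogen on this oxygen without the minimum effective dose moving beyond the usual scatter, something the earlier comparison of two different cores could not show. Nothing measured here offers an explanation for why the reading holds.

From the compounds shown here alone, a single methyl is a small addition, so it remains open how much more this position tolerates, for instance whether a longer chain such as butyl on the oxygen, or an amine or a carboxylic acid on the ring in place of the hydroxy group, would shift the dose needed. One step at one position also says nothing about the rest of the core of compound 1, where other changes could behave quite differently.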